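Methoxy in place of fluoro: notes on compound 3

This account rests on a few compounds, and the source may have more. Where it says the series, first, only, none or still open, it means among the compounds named here.

Measured in a functional assay on MKN-28 cells (Homo sapiens) for cytotoxicity, read by MTT assay; on this read-out higher numbers stand for weaker inhibition and lower numbers for stronger inhibition:
compound 1 `C=C1C(=O)[C@]23C[C@@]1(F)CC[C@H]2[C@@]12C=CC(=O)[C@](C)(C(=O)O1)[C@H]2[C@@H]3C(=O)OC`: 4100 nM
compound 2 `C=C1C(=O)[C@]23C[C@@]1(F)CC[C@H]2[C@@]12C=CC(=O)[C@](C)(C(=O)O1)[C@H]2[C@@H]3C(=O)OCc1ccccc1`: 9800 nM

Of these two numbers, compound 2 has the higher, 9800 nM, which makes it the weaker inhibitor of the pair, with compound 1 as its nearest neighbour. Next to be read is compound 3 `C=C1C(=O)[C@]23C[C@@]1(OC)CC[C@H]2[C@@]12C=CC(=O)[C@](C)(C(=O)O1)[C@H]2[C@@H]3C(=O)OCc1ccccc1`, which differs from compound 2 by methoxy in place of fluoro on a saturated ring carbon.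

The series offers one measured step, a 2.4-fold higher number from compound 1 to compound 2 (0.38 log units; beyond the scatter). It is modest and concerns a saturated chain carbon bound to an oxygen next to a carbonyl group, not the ring carbon changed here. Among the measured compounds shown here, it therefore sets a rough scale but no direction, and no measurement yet tests a change at this ring carbon. On that scale, no step beyond the scatter is expected in this assay, and the expected step is a 1.0-fold higher number from compound 2 to compound 3 (0.01 log units; within the scatter). Compound 3 is estimated at 10000 nM, with an expected range of 4000 nM to 25000 nM.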

Compound 3, half-maximal inhibitory concentration: 800 nM
For compound 3 the middle estimate is 13-fold (1.10 log units) above the measured one; measured number outside the range, below it.
By their numbers in this assay, from the lowest: compound 3; then compound 1; then compound 2.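

In this assay, the saturated ring carbon two ring bonds from the ring atom that bears two fused rings proves highly responsive to its substituent: methoxy in place of fluoro gives a 12-fold lower number from compound 2 to compound 3 (1.09 log units; beyond the scatter), a large step towards stronger inhibition. The only earlier step, a 2.4-fold higher number from compound 1 to compound 2 (0.38 log units; beyond the scatter), is modest and lies at a saturated chain carbon bound to an oxygen next to a carbonyl group, so among the compounds shown, the larger change in this read-out comes from the ring carbon. No supporting measurement bears on why methoxy and fluoro differ so strongly here, and the step stands as an observation only.

The compounds shown do not settle whether the gain is specific to methoxy or would also appear with a hydroxyl, an ethoxy group or an amine on this ring carbon. From the compounds shown here alone, it also remains open whether the same exchange would give a step of similar size with the methyl ester of compound 1 in place of the benzyl ester of compound 2.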